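Hydroxy to carboxy on the shared core: working notes

The source may hold more compounds than are shown below. What is called first, only, known or untested is meant among the compounds shown, and "the series" means these compounds.

Measured in a functional assay on A-375 cells (Homo sapiens) for antiproliferative activity, read by MTT assay, with a stated time of 24 h, tested at 100 ug/mL; on this read-out lower numbers stand for a weaker effect and higher numbers for a stronger effect at the one concentration tested:
compound 1 `Cc1ccc2nc(C(=O)Nc3c(F)cc(-c4cccc(F)c4)cc3F)c(C)c(O)c2c1` gives 56.4%
compound 2 `COc1ccc2nc(C(=O)Nc3ccc(-c4ccccc4)cc3)c(C)c(O)c2c1` gives 66.9%
compound 3 `Cc1ccc2nc(C(=O)Nc3c(F)cc(-c4cccc(F)c4)cc3F)c(C)c(C(=O)O)c2c1` gives 37.3%

Compound 3 differs from compound 1 by carboxy in place of hydroxy on an aromatic carbon. That change gave a number 19.1 percentage points lower from compound 1 to compound 3 (beyond the scatter). Compound 2 stands highest of the three, with compound 1 nearest and compound 3 furthest, both gaps beyond the scatter. How the core of compound 2 differs from the core of compound 1 is not broken down here.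

Compound 4 `COc1ccc2nc(C(=O)Nc3ccc(-c4ccccc4)cc3)c(C)c(C(=O)O)c2c1` differs from compound 2 by carboxy in place of hydroxy on an aromatic carbon. The place is described in the same words as for the pair of compound 1 and compound 3, so this is the same change, made on the core of compound 2 instead. Among the compounds with values here, with only one measured example of this change, the expectation rests on that pair alone: the step is expected to be a number 18.9 percentage points lower from compound 2 to compound 4 (beyond the scatter), about the size seen from compound 1 to compound 3.

In this assay compound 4 is therefore estimated at 48%, expected within 35% to 60%.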

Compound 4, a percentage reported as inhibition, at one concentration (the size of the read-out at that concentration, not a potency): 70.2%
For compound 4 the middle estimate is 22.2 percentage points below the measured one; measured number outside the range, above it.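

In this assay, the change from hydroxy to carboxy did not carry over from one core to the other: the same change on two cores in this assay, a number 19.1 percentage points lower (beyond the scatter) from compound 1 to compound 3 and a number 3.3 percentage points higher (within the scatter) from compound 2 to compound 4, 22.4 percentage points apart, beyond the scatter of two such steps. Within the data shown here, on the core of compound 2 the change gave a number 3.3 percentage points higher from compound 2 to compound 4 (within the scatter), whereas on the core of compound 1 it gave a number 19.1 percentage points lower from compound 1 to compound 3 (beyond the scatter), so the step measured on one core is no guide to the step on the other in these two pairs. This does not show which of the several differences between the two cores matters, and two pairs give no rule for any further core.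

On these data alone, it remains open whether the change behaves as on the core of compound 1 or as on the core of compound 2 when a core carries only one of those differences. Also open, as far as these compounds go, is how other groups on the same aromatic carbon, such as an amine, a nitrile or a methyl ester, would behave on each of the two cores.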